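The compounds below may be only part of what the source reports. "The series", "measured", "known", "first", "only" and "open" are said of these compounds alone.

Compounds measured so far in a functional assay on A549 cells (Homo sapiens) for inhibition, read by MTT assay, with a stated time of 72 h; a lower number here means a stronger inhibitor, a higher number a weaker inhibitor
- compound 1 `COc1cc(OC)c(C(=O)/C=C/c2ccccc2OC)c(OC)c1` gives 19800 nM
- compound 2 `COc1cc(OC)c(C(=O)/C=C/c2ccc(O)c(O)c2)c(OC)c1` gives 8200 nM
- compound 3 `COc1cc(OC)c(C(=O)/C=C/c2ccc(C(F)(F)F)cc2)c(OC)c1` gives 14200 nM

Compound 3 at 14200 nM lies within the scatter of compound 1 and also within the scatter of compound 2, so its value cannot be set apart from either of them. The next compound, compound 4 `COc1cc(OC)c(C(=O)/C=C/c2ccc(N)cc2)c(OC)c1`, has amino in place of trifluoromethyl on an aromatic carbon, para to a large group, and is otherwise the same: amino in place of trifluoromethyl on an aromatic carbon. Going by the values given here, only one measured step bears on this change, and only loosely. That step, a 2.4-fold lower number from compound 1 to compound 2 (0.38 log units; beyond the scatter), also exchanges the groups on the aromatic ring, and it is modest. However, it involves different groups, and no measured step shows what amino does in place of trifluoromethyl. A single step sets no pattern, so it offers only a weak hint of direction. In this assay a small move towards a lower number is therefore expected, most likely one that stays within the scatter. The estimate amounts to a 1.6-fold lower number from compound 3 to compound 4 (0.20 log units; within the scatter), which is an expected change and not a measured one. Compound 4 is estimated at 9000 nM with an expected range from 3500 nM to 20000 nM.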

Compound 4, half-maximal inhibitory concentration: > 50000 nM
Compound 4 was reported as a limit (the forecaster's own chance of this, stated with the estimate: 3%); middle value at least 5.5-fold (0.74 log units) from the limit.
By their numbers in this assay, from the lowest: compounds 2, 3 and 1 (each within the scatter of the next, the first and the last beyond it). At a limit, above all of these: compound 4.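

In this assay compound 4 is reported only as a limit and not as a number: the limit of > 50000 nM in this assay, at which 1 of the 4 values shown sits.

Amino in place of trifluoromethyl on this aromatic carbon, para to a large group, gives an at least 3.5-fold higher number from compound 3 to compound 4 (0.54 log units; beyond the scatter), the first measured step at this place, and it shows that the group held there can move the number beyond the scatter. The comparisons with the other two ring patterns point the same way, with 4-aminophenyl in place of 3,4-dihydroxyphenyl giving an at least 6.0-fold higher number from compound 2 to compound 4 (0.78 log units; beyond the scatter) and 4-aminophenyl in place of 2-methoxyphenyl giving an at least 2.5-fold higher number from compound 1 to compound 4 (0.40 log units; beyond the scatter), so compound 4 is the weakest of the four, the only one set apart from all the others.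

From the compounds shown here alone, how far the true value of compound 4 lies past the limit stays open, so each of these steps has a lower bound and no measured size. Also open, going by these compounds, is whether a hydroxyl, a dimethylamino or an acetamide group on the same aromatic carbon would follow amino or trifluoromethyl, and a single change at this place cannot settle that.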